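Telluride Sulfate Compound 4 Against Its Selenium Analogue

The compounds below may be only part of what the source reports. "The series", "measured", "known", "first", "only" and "open" are said of these compounds alone.

Values measured so far in a functional assay on HCT-116 cells (Homo sapiens) for cytotoxicity, read by MTT assay, with a stated time of 24 h; on this read-out higher numbers stand for weaker inhibition and lower numbers for stronger inhibition
- Compound 1 (`O=S(=O)(O)OCCCCCCCCCC[Te]c1ccccc1`) gives 7470 nM
- Compound 2 (`O=S(=O)(O)OCCCCCCCC[Te]c1ccccc1`) gives 5990 nM
- Compound 3 (`O=S(=O)(O)OCCCCCCCCC[Se]c1ccccc1`) gives > 100000 nM (a limit, not a number)

Compound 3 stands at the limit of > 100000 nM in this assay, at which 1 of the 3 values shown sits, and so offers a limit rather than a number. Compound 4 (`O=S(=O)(O)OCCCCCCCCC[Te]c1ccccc1`), not yet measured, differs from compound 3 by a single exchange (a group of 7 heavy atoms (6 carbon, 1 tellurium; one six-membered aromatic ring of carbon only) in place of a group of 7 heavy atoms (6 carbon, 1 selenium; one six-membered aromatic ring of carbon only), on a saturated chain carbon, nine bonds along the chain from an oxygen) on the same chain. The step of a 1.2-fold lower number from compound 1 to compound 2 (0.10 log units; within the scatter) is the only measured one that bears on this, and it joins two tellurium compounds whose chains differ in length. The chain of compound 4 is longer than that of compound 2 and shorter than that of compound 1. Among the measured compounds shown here, no measured step exchanges selenium for tellurium directly. With the tellurium group in place, compound 4 is expected to fall close to compound 1 (7470 nM) and compound 2 (5990 nM) in this assay with no gap beyond the scatter. The expected change is an at least 15-fold lower number from compound 3 to compound 4 (1.18 log units; beyond the scatter) in the direction of stronger inhibition, and its size is only an estimate against a limit. For compound 4 the estimated value is 6600 nM with an expected range of 3500 nM to 13000 nM in all.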

Compound 4, half-maximal inhibitory concentration: 4990 nM
The estimate for compound 4 lay 1.3-fold (0.12 log units) above the measured number; low and high end bracket the measured number.
By their numbers in this assay, from the lowest: compounds 4, 2 and 1 (each within the scatter of the next). At a limit, above all of these: compound 3.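

In this assay the tellurium group in place of the selenium group gives an at least 20-fold lower number from compound 3 to compound 4 (1.30 log units; beyond the scatter) and so ties a large gap to this single exchange, on a saturated chain carbon, nine bonds along the chain from an oxygen. Compound 3 stands at a limit and not at a number, so this step has no fixed size: the limit of > 100000 nM in this assay, at which 1 of the 4 values shown sits. Among the three tellurium compounds, chain length produces no step beyond the scatter, with a 1.2-fold lower number from compound 2 to compound 4 (0.08 log units; within the scatter) and a 1.5-fold lower number from compound 1 to compound 4 (0.18 log units; within the scatter) as the two new readings.

Only one selenium compound is shown, so it remains open whether the exchange carries the same weight at other chain lengths. Also open, going by these compounds, is how a sulfur atom in place of the tellurium, or a carboxylic acid or an amine in place of sulfooxy, would read here.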